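A few compounds are considered here, and "the series" means these few. Any claim that something is new, unique, unknown or untested is made for them only; others in the source may bear on it.

Values so far in an ADME assay on a cell-free system (plasma, Mus musculus) for metabolic stability, read by LC-MS, tested at 2 uM; a lower number here means that the compound disappears faster, a higher number that the compound lasts longer:
- Compound 1 `CCCCCNC(=O)n1cc(-c2ccccc2)oc1=O`: > 2 h, a limit.
- Compound 2 `CC(C)CNC(=O)n1cc(-c2ccccc2)oc1=O`: > 2 h, a limit.
- Compound 3 `COc1cccc(-c2cn(C(=O)NCCCCc3ccccc3)c(=O)o2)c1`: > 2 h, a limit.
- Compound 4 `O=C(NCCCCc1ccccc1)n1cc(-c2cnccn2)oc1=O`: not yet measured.

Compound 3 has no number in this assay, only its limit of > 2 h. The series as a whole sits in the same place: the limit of > 2 h in this assay, at which 3 of the 3 values shown sit.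

The change to compound 4 pyrazin-2-yl in place of 3-methoxyphenyl on an aromatic carbon puts pyrazin-2-yl in place of 3-methoxyphenyl on an aromatic carbon. Within the data shown here, the only measured step, a step that the two limits leave unreadable from compound 1 to compound 2, concerns the chain on the amide-type nitrogen and not this place, so it gives no size to carry over. No step beyond the usual scatter is expected, and no direction can be argued; the estimated step is a step that the limit leaves unreadable from compound 3 to compound 4. Compound 4 is again expected to be reported as a limit in this assay. If a number is obtained, compound 4 is estimated at 3 h, with an expected range of 1.2 h to 8 h.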

Compound 4, half-life: 0.667 h
Compound 4: the middle estimate sits 4.5-fold (0.65 log units) above what was measured, and the stated range ends above it.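

In this assay, pyrazin-2-yl in place of 3-methoxyphenyl gives an at least 2.9-fold lower number from compound 3 to compound 4 (0.47 log units; beyond the scatter), the only readable step shown in the series. The aromatic carbon next to the ring oxygen is therefore a position where a change of group can move the half-life beyond the scatter, with the chain on the amide-type nitrogen held constant. Compound 4 is also the only compound shown with a number rather than a limit: the limit of > 2 h in this assay, at which 3 of the 4 values shown sit.

This single pair cannot separate the ring nitrogens of pyrazin-2-yl from the loss of the methoxy group on the phenyl ring. Unsubstituted phenyl and pyridin-2-yl at this position, on the same chain, would help separate the two, and whether the chain on the amide-type nitrogen alters the step remains open.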